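A few compounds are considered here, and "the series" means these few. Any claim that something is new, unique, unknown or untested is made for them only; others in the source may bear on it.

Working notes on the series: in a functional assay on A549 cells (Homo sapiens) for cytotoxicity, read by MTT assay (a lower number here means a stronger inhibitor, a higher number a weaker inhibitor), compound 1 `COc1cc2ncnc(Nc3cc(O)[nH]n3)c2cc1OC` gives 74900 nM, and compound 2 `COc1cc2ncnc(Nc3cc(-c4ccccc4)[nH]n3)c2cc1OC` gives 29700 nM. Compound 3 `COc1cc2ncnc(Nc3cc(-c4ccc(F)cc4)[nH]n3)c2cc1OC` is reported only as a limit, < 100000 nM. That leaves a step that the limit leaves unreadable from compound 1 to compound 3 and a step that the limit leaves unreadable from compound 2 to compound 3.

Compound 4 `COc1cc2ncnc(Nc3cc(-c4ccc(Cl)cc4)[nH]n3)c2cc1OC` carries chloro in place of fluoro on an aromatic carbon, para to a large group: chloro in place of fluoro on an aromatic carbon. Within the data shown here, the only readable measured step is a 2.5-fold lower number from compound 1 to compound 2 (0.40 log units; beyond the scatter), and it concerns a different change. Among the measured compounds shown here, no halogen step has a readable size, so the working figure leans on compound 2 at 29700 nM, and no step beyond the scatter is anticipated in either direction. The estimated change is a step that the limit leaves unreadable from compound 3 to compound 4. Compound 4 is expected at 35000 nM, with an estimated range of 12000 nM to 90000 nM.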

Compound 4, half-maximal inhibitory concentration: < 100000 nM
Compound 4: a limit, no number; the forecaster's own chance of this, stated with the estimate: 35%; the middle value does not contradict the limit.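

Compound 4 is reported only as a limit, so no step from compound 1, compound 2 or compound 3 to compound 4 can be read: the limit of < 100000 nM in this assay, at which 2 of the 4 values shown sit.

On these data alone, whether fluoro or chloro on the phenyl changes the number relative to compound 2 in this assay stays open.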